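Swapping the Aryl Group on the Saturated Ring Carbon

The compounds below may be only part of what the source reports. "The series", "measured", "known", "first", "only" and "open" are said of these compounds alone.

Compound 2 `NS(=O)(=O)c1ccc2nc(N3N=C(c4ccc(Cl)cc4)CC3c3cccs3)sc2c1` carries a thiophen-2-yl group on a saturated ring carbon of the shared core. In a functional assay on the whole organism (strain Wistar) for inhibition, with Rattus norvegicus as the target, read by paw edema, with stated times of 1 h and 5 h, at a dose of 20 mg/kg by the oral route (on this read-out higher numbers stand for more inhibition at the one dose given (going by the name of the read-out) and lower numbers for less inhibition), compound 2 gives 14%. Its nearest neighbour is compound 1 `Cc1ccc(C2CC(c3ccc(Cl)cc3)=NN2c2nc3ccc(S(N)(=O)=O)cc3s2)cc1`, which differs only in bearing 4-methylphenyl on that saturated ring carbon; in this assay compound 1 gives 14%. The step of no change at the digits printed from compound 1 to compound 2 (within the scatter) shows that exchanging one aryl group for another at this saturated ring carbon left the read-out where it was, so compound 2 stands level with compound 1 on the numbers at hand.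

Compound 3 `NS(=O)(=O)c1ccc2nc(N3N=C(c4ccc(Cl)cc4)CC3c3ccccc3Cl)sc2c1` has not yet been measured. It differs from compound 2 by 2-chlorophenyl in place of thiophen-2-yl on a saturated ring carbon. Among the measured compounds shown here, the only measured step that bears on this change is the one from compound 1 to compound 2, where a different exchange of the group on the same saturated ring carbon produced no shift beyond the scatter. On that basis the step is expected to be small, no change at the digits printed from compound 2 to compound 3 (within the scatter), with no direction favoured. Compound 3 is therefore estimated to give 14% in this assay, within a range of 4% to 26%.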

Compound 3, a percentage reported as inhibition, in the whole organism at one dose (the size of the read-out at that dose, not a potency): 14%
The estimate for compound 3 equals the measured number at the digits printed; low and high end bracket the measured number.
By their numbers in this assay, from the lowest: compounds 1, 2 and 3 (each within the scatter of the next).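

With 2-chlorophenyl on the saturated ring carbon, this assay shows no change at the digits printed from compound 2 to compound 3 (within the scatter) and no change at the digits printed from compound 1 to compound 3 (within the scatter), so all three pairs among these compounds now lie within the scatter. The exchange of thiophen-2-yl for 2-chlorophenyl replaces a five-membered aromatic ring holding sulfur, with 5 heavy atoms and 1 hydrogen-bond acceptor, by a six-membered aromatic ring of carbon only that bears chlorine, with 7 heavy atoms and 0 hydrogen-bond acceptors, and this difference leaves no mark on the read-out at this one dose. No separate measurement is available to explain why these three aryl groups give the same read-out.

All three groups at this carbon are aromatic rings, so the compounds shown leave open whether an amine, a carboxylic acid or a longer alkyl chain there would shift the read-out beyond the scatter. They also leave open whether any group at this carbon matters to the read-out, and whether a change to the 4-chlorophenyl group on the same ring would do so.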